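Lengthening the Alkyl Chain on the Acetophenone Core

The source may hold more compounds than are shown below. What is called first, only, known or untested is meant among the compounds shown, and "the series" means these compounds.

Measured compounds:
Compound 1: `CCCc1cc(C(C)=O)c(O)cc1OCCCCC#N` – 37%
Compound 2: `CCCCc1cc(C(C)=O)c(O)cc1OCCCCC#N` – 13%

Compound 2 stands lowest of the two numbers in an assay on isolated protein for binding affinity to leukotriene B4 receptor 1 (Homo sapiens), tested at 1 uM; on this read-out higher numbers stand for more inhibition at the one concentration tested (going by the name of the read-out) and lower numbers for less inhibition; its nearest neighbour is compound 1, which gives 37% in this assay. Going by the values given here, the one step seen so far, a number 24 percentage points lower from compound 1 to compound 2 (beyond the scatter), went downward. Compound 3 `CCCCCc1cc(C(C)=O)c(O)cc1OCCCCC#N` has not yet been measured; it continues the same direction of change: methyl in place of hydrogen on a saturated chain carbon, four bonds along the chain from an aromatic carbon. Among the compounds with values here, the only step that bears on it is the one from compound 1 to compound 2, and compound 3 starts from a lower position, so there is less room left on the scale. Compound 3 is therefore expected to give a smaller downward step, a number 7 percentage points lower from compound 2 to compound 3 (within the scatter), in this assay. The estimate for compound 3 in this assay is 6%, with a range from -8% to 22%.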

Compound 3, a percentage reported as inhibition, at one concentration (the size of the read-out at that concentration, not a potency): 14%
Compound 3: the middle estimate sits 8 percentage points below what was measured, within the range that was stated.
By their numbers in this assay, from the lowest: compounds 2 and 3 (each within the scatter of the next); then compound 1.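

In this assay, methyl in place of hydrogen on a saturated chain carbon, four bonds along the chain from an aromatic carbon, gives a number 1 percentage points higher from compound 2 to compound 3 (within the scatter), so the fall seen with the first added methyl does not carry on at this position. The two extensions taken together give a number 23 percentage points lower from compound 1 to compound 3 (beyond the scatter), which is about the same size as the earlier step, and so across these three compounds the whole loss lies in the first extension. Nothing available here accounts for this flat second step.

The compounds shown leave open whether a longer chain would stay at this low level or move away from it. They also leave open how a chain carrying an amine or a carboxylic acid would read at this position.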